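This account rests on a few compounds, and the source may have more. Where it says the series, first, only, none or still open, it means among the compounds named here.

Compound 1 `CCCCc1ccc(CN(CCCCOCC(=O)O)S(C)(=O)=O)cc1` gives 701 nM in an assay on HEK293 cells for inhibition of prostaglandin E2 receptor EP2 subtype (Rattus norvegicus); a lower number here means a stronger inhibitor, a higher number a weaker inhibitor. Compound 2 `CC(C)(C)c1ccc(CN(Cc2cccc(CCC(=O)O)c2)S(=O)(=O)c2ccccn2)cc1` gives 52 nM in this assay. Compound 3 `CS(=O)(=O)N(CCCCCCC(=O)O)Cc1ccc(-c2ccccc2)cc1` gives 289 nM in this assay. Compound 3 thus stands second highest of the three numbers, beyond the scatter from compound 1 on the higher side and from compound 2 on the lower side. Compound 4 `CCCCCC(=O)c1ccc(CN(CCCCCCC(=O)O)S(C)(=O)=O)cc1` has not yet been measured. It differs from compound 3 in one place: pentylcarbonyl in place of phenyl on an aromatic carbon. Among the measured compounds shown here, no measured pair carries this exchange, so the expectation rests on the surrounding numbers only. A small step toward a higher number, near the scatter, is expected: a 1.4-fold higher number from compound 3 to compound 4 (0.14 log units; within the scatter). Compound 4 is therefore estimated at 400 nM, with a range from 150 nM to 1100 nM.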

Compound 4, half-maximal inhibitory concentration: 636 nM
The estimate for compound 4 lay 1.6-fold (0.20 log units) below the measured number; the measured number falls inside the stated range.
By their numbers in this assay, from the lowest: compound 2; then compound 3; then compounds 4 and 1 (each within the scatter of the next).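

Pentylcarbonyl in place of phenyl on this aromatic carbon, para to a large group, gives a 2.2-fold higher number from compound 3 to compound 4 (0.34 log units; beyond the scatter). This position therefore tolerates an open chain without a ring, with a modest weakening of inhibition that lies beyond the scatter. No measurement at hand accounts for the step.

On these data alone, whether the weakening follows the loss of the ring or the arrival of the carbonyl remains open. A plain hexyl chain and a benzoyl group on the same carbon would separate the two, and neither is among the compounds shown.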